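Swapping one amino group on a long-lived compound

The compounds below may be only part of what the source reports. "The series", "measured", "known", "first", "only" and "open" are said of these compounds alone.

In an ADME assay on a cell-free system (serum) for metabolic stability (on this read-out higher numbers stand for a longer-lived compound and lower numbers for a shorter-lived compound), compound 1 (`CC(C)(C)c1cc(OC(=O)c2ccco2)ccc1O`) gives < 0.25 h as its result, which is a limit and not a number. Compound 2 (`CC(C)(C)c1cc(OC(=O)c2ccc(Cl)cc2)ccc1O`) gives < 0.25 h as its result, and this too is a limit. In this assay compound 3 (`CC(C)(C)c1cc(NC(=O)c2c(Cl)cc(NCc3cccs3)cc2Cl)ccc1O`) gives > 1 h as its result, again a limit and not a number. It therefore stands on the longer-lived side of compound 1 and compound 2, without a number of its own.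

Compound 4 (`CN(c1cc(Cl)c(C(=O)Nc2ccc(O)c(C(C)(C)C)c2)c(Cl)c1)C1CCCCC1`) carries cyclohexyl(methyl)amino in place of ((thiophen-2-yl)methyl)amino on an aromatic carbon, and the rest of compound 3 stays as it is. Within the data shown here, the only measured step between two compounds that differ in one place (a step that the two limits leave unreadable from compound 1 to compound 2) falls elsewhere on the structure, and its size cannot be read, which leaves it no guide here. The expectation therefore rests on compound 3 alone, whose limit is > 1 h in this assay with no measured size for a swap of this kind. No step beyond the usual scatter is expected, and the estimated step (a step that the limit leaves unreadable from compound 3 to compound 4) could go in either direction. In this assay the estimate for compound 4 is 2 h with an expected range from 0.7 h to 6 h and the result may again be only a limit.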

Compound 4, half-life: > 1 h
Compound 4 gave a limit, no number; the forecaster's own chance of this, stated with the estimate: 70%; the middle value does not contradict the limit.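

In this assay, compound 3 and compound 4 each give only a limit and not a number, and the step between these two compounds cannot be read. From the compounds shown here alone, what stays open is how long either compound really lasts, and whether cyclohexyl(methyl)amino in place of ((thiophen-2-yl)methyl)amino changes that at all.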